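The source may hold more compounds than are shown below. What is called first, only, known or untested is meant among the compounds shown, and "the series" means these compounds.

Compound 1 `CCCCCCCCOC(=O)CCC(=O)N1CCN(CCCOc2cc3c(Nc4ccc(F)c(Cl)c4)ncnc3cc2OC)CC1` gives 26% in a functional assay on A549 cells (Homo sapiens) for cytotoxicity, read by MTT assay, with a stated time of 24 h, tested at 60 uM; on this read-out lower numbers stand for a stronger effect and higher numbers for a weaker effect at the one concentration tested. Compound 2 `CCCCCCCCCCCCOC(=O)CCC(=O)N1CCN(CCCOc2cc3c(Nc4ccc(F)c(Cl)c4)ncnc3cc2OC)CC1` gives 2%. Compound 3 `CCCCCCCCCCCCCCCCOC(=O)CCC(=O)N1CCN(CCCOc2cc3c(Nc4ccc(F)c(Cl)c4)ncnc3cc2OC)CC1` gives 80%.

Compound 3 stands highest of the three numbers, above compound 1 and further still above compound 2. The measured steps do not run one way: a number 24 percentage points lower from compound 1 to compound 2 (beyond the scatter), whereas a number 54 percentage points higher from compound 1 to compound 3 (beyond the scatter) and a number 78 percentage points higher from compound 2 to compound 3 (beyond the scatter). Compound 4 `CCCCCCCCCCCCCCCCCCCOC(=O)CCC(=O)N1CCN(CCCOc2cc3c(Nc4ccc(F)c(Cl)c4)ncnc3cc2OC)CC1` differs from compound 3 in one place: propyl in place of hydrogen on a saturated chain carbon, ten or more bonds along the chain from an oxygen next to a carbonyl group. The two steps that lengthen the chain beyond compound 2 bear most on this change, and both were large and upward; compound 3, however, already lies near the top of the scale, so in this assay only a small further rise is expected, one not beyond the scatter, with a number 8 percentage points higher from compound 3 to compound 4 (within the scatter). Compound 4 is therefore estimated at 88%, between 62% and 100%.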

Compound 4, a percentage reported as activity, at one concentration (the size of the read-out at that concentration, not a potency): 89.3%
Beside the measured number, compound 4's estimate is 1.3 percentage points below it; the range from low to high includes it.
By their numbers in this assay, from the lowest: compound 2; then compound 1; then compounds 3 and 4 (each within the scatter of the next).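

In this assay, among the compounds shown here, propyl in place of hydrogen on the chain gives a number 9.3 percentage points higher from compound 3 to compound 4 (within the scatter) and so, unlike the earlier steps, this lengthening moves the number by no more than the scatter. The weak effect seen at compound 3 persists in the longer chain, with a number 87.3 percentage points higher from compound 2 to compound 4 (beyond the scatter) and a number 63.3 percentage points higher from compound 1 to compound 4 (beyond the scatter) on the same side. Among these compounds, the effect is lost beyond compound 2 and does not return in compound 4.

Nothing shown gives a reason for this pattern. From the compounds shown here alone, whether a chain ending in an amine or a carboxylic acid would restore the effect stays open, as does where between the chains of compound 2 and compound 3 the effect falls away.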